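Trading Bromine for Chlorine on the Fused Ring

The compounds below may be only part of what the source reports. "The series", "measured", "known", "first", "only" and "open" are said of these compounds alone.

Going by the values given here, compound 3 `CN(C)c1ccc(C2CC(c3ccccc3)=NN2C2=NC(=O)/C(=C3\C(=O)Nc4ccc(Br)cc43)S2)cc1` gives 220 nM in a functional assay on cells (Cancer cell lines, Homo sapiens) for cytotoxicity, read by sulforhodamine B assay, with a stated time of 48 h (on this read-out higher numbers stand for weaker inhibition of growth and lower numbers for stronger inhibition of growth), the lowest of the three numbers measured so far. Compound 1 `O=C1N=C(N2N=C(c3ccccc3)CC2c2ccccc2O)S/C1=C1/C(=O)Nc2ccc(Br)cc21` gives 240 nM, and the step of a 1.1-fold lower number from compound 1 to compound 3 (0.04 log units; within the scatter) shows that the two stand together. Compound 2 `CN(C)c1ccc(C2CC(c3ccccc3)=NN2C2=NC(=O)/C(=C3\C(=O)Nc4ccccc43)S2)cc1` gives 7420 nM, and the step of a 34-fold lower number from compound 2 to compound 3 (1.53 log units; beyond the scatter) sets it far apart from both.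

Compound 4 `CN(C)c1ccc(C2CC(c3ccccc3)=NN2C2=NC(=O)/C(=C3\C(=O)Nc4ccc(Cl)cc43)S2)cc1` differs from compound 3 in one place: chloro in place of bromo on an aromatic carbon. Among the compounds with values here, only one measured step touches this position, the step from compound 2 to compound 3, which was large; it shows that a halogen at this site, compared with hydrogen, moves the number a long way down. Within the data shown here, no measured pair shows chloro against bromo at this position, so the size of the present step has to be read as a guess. A halogen remains in place, so the bulk of what the step from compound 2 to compound 3 gained is expected to be kept, with at most a small drift toward a higher number.

Compound 4 is therefore expected to come in near 380 nM, within a range from 150 nM to 1000 nM in this assay. The estimated step of a 1.7-fold higher number from compound 3 to compound 4 (0.24 log units; within the scatter) is expected to lie within the scatter.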

Compound 4, concentration for 50% growth inhibition: 210 nM
Compound 4: middle estimate off by 1.8-fold (0.26 log units), on the high side; the range from low to high includes it.
By their numbers in this assay, from the lowest: compounds 4, 3 and 1 (each within the scatter of the next); then compound 2.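

In this assay the exchange of one halogen for the other at this position makes no difference that can be told apart (a 1.0-fold lower number from compound 3 to compound 4 (0.02 log units; within the scatter)), so chloro and bromo on this aromatic carbon stand together. The large gain over hydrogen is therefore not tied to bromo alone: the step with chloro (a 35-fold lower number from compound 2 to compound 4 (1.55 log units; beyond the scatter)) is of the same size as the step with bromo (a 34-fold lower number from compound 2 to compound 3 (1.53 log units; beyond the scatter)), and the two compounds carrying a halogen here lie far from compound 2, which carries hydrogen. Nothing available accounts for why the two halogens behave alike at this site.

As far as these compounds go, what stays open is whether the gain belongs to chloro and bromo only or also extends to other groups on this carbon, such as fluoro, methoxy or an amine. From the compounds shown here alone, it is also open whether chloro would stand level with bromo on a compound carrying 2-hydroxyphenyl in place of 4-(dimethylamino)phenyl on the saturated ring carbon, since only the second of these two groups has been seen with chloro.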